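Series notes: hydroxy to ethoxy step toward compound 3

This account rests on a few compounds, and the source may have more. Where it says the series, first, only, none or still open, it means among the compounds named here.

Compound 2 `Oc1ccc(/C=N\NC(=S)NC2CCCCC2)cc1` stands lowest of the two numbers measured in a functional assay on MCF7 cells (Homo sapiens) for inhibition, read by WST assay, with a stated time of 48 h; on this read-out lower numbers stand for stronger inhibition and higher numbers for weaker inhibition: compound 2 gives 50400 nM, while compound 1 `S=C(N/N=C\c1ccc(Cl)cc1)NC1CCCCC1` gives 91400 nM. Among the measured compounds shown here, the only measured step, a 1.8-fold lower number from compound 1 to compound 2 (0.26 log units; within the scatter), is hydroxy in place of chloro on an aromatic carbon and lies within the scatter. Compound 3 `CCOc1ccc(/C=N\NC(=S)NC2CCCCC2)cc1` differs from compound 2 by ethyl in place of hydrogen on an oxygen on an aromatic ring; cut one bond further out, the change reads hydroxy to ethoxy. For the measured compounds named here, no measured step bears directly on this change: the one known step touches a different group and was itself within the scatter. Accordingly, in this assay no step beyond the scatter is expected for compound 3, estimated as a 1.0-fold lower number from compound 2 to compound 3 (0.00 log units; within the scatter). Compound 3 is estimated at 50000 nM, with a range from 18000 nM to 140000 nM.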

Compound 3, half-maximal inhibitory concentration: 166000 nM
Compound 3: the middle estimate sits 3.3-fold (0.52 log units) below what was measured; the whole stated range lies below it.
By their numbers in this assay, from the lowest: compounds 2, 1 and 3 (each within the scatter of the next, the first and the last beyond it).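

In this assay, among the compounds shown here, ethyl in place of hydrogen on the oxygen on the aromatic ring gives the only step that passes the scatter (a 3.3-fold higher number from compound 2 to compound 3 (0.52 log units; beyond the scatter)), so this oxygen is the first place where a change separates two compounds on this read-out. The direction is toward weaker inhibition: the free hydroxy of compound 2 is not matched by its ethoxy counterpart, compound 3. Against the chloro group, ethoxy stays within the scatter (a 1.8-fold higher number from compound 1 to compound 3 (0.26 log units; within the scatter)), so compound 1 and compound 3 cannot be told apart, and only compound 2 and compound 3 stand clear of each other.

No measured property of these compounds accounts for the step. Open, on these data alone, is whether a methoxy on the same oxygen or an amine in place of the hydroxy stays level with compound 2, and whether a longer chain such as propoxy moves the number further.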